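The compounds below may be only part of what the source reports. "The series", "measured", "known", "first", "only" and "open" are said of these compounds alone.

Compound 2 `Cn1cc(-c2cccc3c2CCC3c2ncc[nH]2)cn1` carries a 1-methyl-1H-pyrazol-4-yl on the aromatic ring of the shared core. In a functional assay on CHO cells for agonist activity at Alpha-1D adrenergic receptor (Homo sapiens), read by FLIPR and calcium flux (a lower number here means that less compound is needed, a higher number that more compound is needed for the effect), compound 2 gives > 10000 nM, which is a limit of the assay and not a number. Compound 1 `Clc1ccc2c(c1-c1ccn[nH]1)CCC2c1ncc[nH]1` gives > 10000 nM in this assay, also a limit. Both therefore sit at the limit of > 10000 nM in this assay, at which 2 of the 3 values shown sit. Among the measured compounds shown here, compound 3 `c1ccc2c(c1)CCCC2c1ncc[nH]1`, which bears no substituent on its aromatic ring and has a larger saturated ring, gives 364 nM in this assay, the only number among the three.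

Compound 4 `Cn1nccc1-c1cccc2c1CCC2c1ncc[nH]1` is still to be measured. It differs from compound 2 in a single place: 1-methyl-1H-pyrazol-5-yl in place of 1-methyl-1H-pyrazol-4-yl on an aromatic carbon. For the measured compounds named here, no step between measured compounds is available to calibrate such a change, so the expectation rests on the two compounds with a pyrazole on that ring, which both return only a limit. Compound 1 already places a pyrazole attached through a ring carbon that neighbours a ring nitrogen and stays at the limit, and compound 4 adopts the same kind of attachment with a methyl on that nitrogen. The author therefore expects a step that the limit leaves unreadable from compound 2 to compound 4, that is, no movement beyond the scatter, and compound 4 is estimated at 12000 nM with a range from 3000 nM to 50000 nM, most likely again reported only as a limit.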

Compound 4, half-maximal effective concentration: > 10000 nM
Compound 4: no number, only a limit; the forecaster's own chance of this, stated with the estimate: 70%; the middle value is on the limit's open side.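

In this assay, compound 4 returns only a limit of the assay, as compound 2 does, so no step can be read for 1-methyl-1H-pyrazol-5-yl in place of 1-methyl-1H-pyrazol-4-yl: the limit of > 10000 nM in this assay, at which 3 of the 4 values shown sit.

The compounds shown leave open where the true values of compound 2 and compound 4 lie, and whether those two values differ at all.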